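Ring contraction on the amide of compound 2

A few compounds are considered here, and "the series" means these few. Any claim that something is new, unique, unknown or untested is made for them only; others in the source may bear on it.

Compound 1 `COc1ccc(-n2nc(Sc3ccc(Cl)cc3)cc(CCC(=O)N[C@@H]3CCc4ccccc4NC3=O)c2=O)cc1` gives 3060 nM in a functional assay with Melanocortin receptor 4 (Homo sapiens) as the target, read by cAMP accumulation; on this read-out higher numbers stand for an effect only at larger amounts of compound and lower numbers for an effect already at smaller amounts. Compound 2 `COc1ccc(-n2nc(Sc3ccc(Cl)cc3)cc(CCCNC(=O)[C@H]3CCNC[C@@H]3c3ccccc3)c2=O)cc1` is reported in this assay only as a limit of > 5000 nM, not as a number. That limit is the limit of > 5000 nM in this assay, at which 1 of the 2 values shown sits, so the position of compound 2 is known only as lying beyond the range the assay resolves. Compound 3 `COc1ccc(-n2nc(Sc3ccc(Cl)cc3)cc(CCCNC(=O)[C@H]3CNC[C@@H]3c3ccccc3)c2=O)cc1` differs from compound 2 in one place: 4-phenylpyrrolidin-3-yl in place of 3-phenylpiperidin-4-yl on a carbonyl carbon. No measured step of this kind stands among the compounds shown, so the size and direction of its effect in this assay are open. Since compound 2 itself already sits at the limit, the step from compound 2 to compound 3 is expected to be a step that the limit leaves unreadable from compound 2 to compound 3, most likely without a resolved number at the far end. For compound 3 the estimated value in this assay is 8000 nM, expected to fall between 2000 nM and 30000 nM.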

Compound 3, half-maximal effective concentration: 820 nM
Estimate against measurement, compound 3: 9.8-fold (0.99 log units) above, outside the stated range (below it).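

In this assay, the group on the carbonyl carbon responds to ring size: going from the six-membered to the five-membered non-aromatic ring gives an at least 6.0-fold lower number from compound 2 to compound 3 (0.78 log units; beyond the scatter), a step beyond the scatter. The hydrogen-bond donor and acceptor counts of the group stay the same across this step, and the phenyl ring is kept. The reported step is a lower bound, since compound 2 is known only as a limit: the limit of > 5000 nM in this assay, at which 1 of the 3 values shown sits.

The compounds shown do not tell whether the trend continues to a smaller ring such as azetidine, or whether a methyl or acetyl group on the ring nitrogen would keep the lower number. Compound 1 differs from compound 3 in more than one place, so the effect of its amide arrangement remains unresolved.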